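Swapping the Quinoline Amide for a Benzothiophene Amide

The source may report more compounds than this note shows. Statements on the series, on what has been measured and on what is new or still open speak of the compounds shown alone.

Compound 3 `CN1[C@@H]2c3[nH]c4ccccc4c3C[C@H]1[C@H](C#N)N1[C@@H](CNC(=O)c3ccc4ccccc4n3)c3[nH]c4ccccc4c3C[C@@H]21` gives 150 nM in a functional assay on MCF7 cells (Homo sapiens) for cytotoxicity, read by MTT assay, with a stated time of 72 h (on this read-out higher numbers stand for weaker inhibition and lower numbers for stronger inhibition), the lowest number among the three measured compounds. Compound 1 `CN1[C@@H]2c3[nH]c4ccccc4c3C[C@H]1[C@H](C#N)N1[C@@H](CNC(=O)c3cccc4c3CCCC4)c3[nH]c4ccccc4c3C[C@@H]21` gives 4470 nM and compound 2 `CN1[C@@H]2c3[nH]c4ccccc4c3C[C@H]1[C@H](C#N)N1[C@@H](CNC(=O)c3ccc4ccccc4c3)c3[nH]c4ccccc4c3C[C@@H]21` gives 4650 nM; both steps, a 30-fold lower number from compound 1 to compound 3 (1.47 log units; beyond the scatter) and a 31-fold lower number from compound 2 to compound 3 (1.49 log units; beyond the scatter), were large. Compound 4 `CN1[C@@H]2c3[nH]c4ccccc4c3C[C@H]1[C@H](C#N)N1[C@@H](CNC(=O)c3cc4ccccc4s3)c3[nH]c4ccccc4c3C[C@@H]21` carries 1-benzothiophen-2-yl in place of quinolin-2-yl on a carbonyl carbon. The closest guide is the step from compound 2, since naphthalen-2-yl and 1-benzothiophen-2-yl both lack the ring nitrogen that quinolin-2-yl brings, and that step, a 31-fold lower number from compound 2 to compound 3 (1.49 log units; beyond the scatter), was large. Compound 4 is therefore expected to give a higher number than compound 3, with the step estimated as a 13-fold higher number from compound 3 to compound 4 (1.12 log units; beyond the scatter). Compound 4 is estimated at 2000 nM, within a range from 500 nM to 6000 nM.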

Compound 4, half-maximal inhibitory concentration: 3180 nM
The estimate for compound 4 lay 1.6-fold (0.20 log units) below the measured number; low and high end bracket the measured number.
By their numbers in this assay, from the lowest: compound 3; then compounds 4, 1 and 2 (each within the scatter of the next).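

In this assay, replacing quinolin-2-yl on this carbonyl carbon with 1-benzothiophen-2-yl proves costly, with a 21-fold higher number from compound 3 to compound 4 (1.33 log units; beyond the scatter). A sulfur-bearing five-membered aromatic ring thus does not stand in for the quinolin-2-yl group: the result sits with the two compounds lacking a ring nitrogen, at a 1.5-fold lower number from compound 2 to compound 4 (0.17 log units; within the scatter) and a 1.4-fold lower number from compound 1 to compound 4 (0.15 log units; within the scatter). Among these four compounds, the lowest number stays with the only group carrying a ring nitrogen, and none goes against this.

Still open, going by these compounds, is whether that nitrogen alone carries the difference, which a benzothiazol-2-yl group, holding nitrogen and sulfur together, could help test. Nothing available here explains the link between the ring nitrogen and the lower number.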